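The source may hold more compounds than are shown below. What is called first, only, known or untested is meant among the compounds shown, and "the series" means these compounds.

Measured compounds:
- compound 1, `CCN(CC)CCn1cnnc1-c1cc(Oc2ccc(NC(=O)Nc3ccc(F)c(Cl)c3)cc2F)ccn1`: 34000 nM
- compound 2, `CN(C)CCCn1cnnc1-c1cc(Oc2ccc(NC(=O)Nc3ccc(Cl)c(C(F)(F)F)c3)cc2F)ccn1`: 7880 nM
- compound 3, `CN(C)CCCn1cnnc1-c1cc(Oc2ccc(NC(=O)Nc3ccccc3C(F)(F)F)cc2F)ccn1`: 40500 nM

In a functional assay on MDA-MB-231 cells (Homo sapiens) for antiproliferative activity, read by MTT assay, with a stated time of 72 h (on this read-out higher numbers stand for weaker inhibition and lower numbers for stronger inhibition), compound 3 gives the highest of the three numbers: it sits close to compound 1, whose value of 34000 nM is within the scatter of it, and well apart from compound 2, whose value of 7880 nM is beyond the scatter. Within the data shown here, the one directly comparable step is a 5.1-fold higher number from compound 2 to compound 3 (0.71 log units; beyond the scatter), which shows that the choice of the aryl group on the urea nitrogen moves the number by a modest amount.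

Compound 4, `CN(C)CCCn1cnnc1-c1cc(Oc2ccc(NC(=O)Nc3ccc(F)c(Cl)c3)cc2F)ccn1`, differs from compound 3 by 3-chloro-4-fluorophenyl in place of 2-(trifluoromethyl)phenyl on an amide-type nitrogen. Among the measured compounds shown here, compound 1 carries the same 3-chloro-4-fluorophenyl group on a different amine chain, and its value lies within the scatter of compound 3; no step between compound 1 and compound 4 is given, so only those two numbers speak. Because the step of a 5.1-fold higher number from compound 2 to compound 3 (0.71 log units; beyond the scatter) was modest, and because compound 1 with 34000 nM is no lower than compound 3, compound 4 is expected to show at most a small lowering, a 2.0-fold lower number from compound 3 to compound 4 (0.31 log units; beyond the scatter). Compound 4 is therefore estimated at 20000 nM in this assay, with a range from 6000 nM to 60000 nM.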

Compound 4, half-maximal inhibitory concentration: 14200 nM
The estimate for compound 4 lay 1.4-fold (0.15 log units) above the measured number, within the range that was stated.
By their numbers in this assay, from the lowest: compounds 2 and 4 (each within the scatter of the next); then compounds 1 and 3 (each within the scatter of the next).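

In this assay the 3-chloro-4-fluorophenyl group on the amide-type nitrogen gives a 2.9-fold lower number from compound 3 to compound 4 (0.46 log units; beyond the scatter) when it replaces 2-(trifluoromethyl)phenyl, so this position responds to more than the one earlier exchange had shown. Against 4-chloro-3-(trifluoromethyl)phenyl the same group gives a 1.8-fold higher number from compound 2 to compound 4 (0.26 log units; within the scatter) and so cannot be told apart from it, which leaves 2-(trifluoromethyl)phenyl as the group that stands apart among these three. Among these compounds, with the aryl group held constant, the first reading of the amine side is a 2.4-fold lower number from compound 1 to compound 4 (0.38 log units; beyond the scatter) for (dimethylamino)methyl in place of diethylamino, a step resting on this single pair.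

From the compounds shown here alone, whether that amine step holds with other aryl groups stays open, as does how a morpholine on the chain or a plain phenyl on the amide-type nitrogen would read. The data shown offer no independent measurement that bears on why these steps arise.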